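The compounds below may be only part of what the source reports. "The series", "measured", "known", "first", "only" and "open" are said of these compounds alone.

Measured compounds:
Compound 1, `COc1cc(/C=C/C(=O)c2cccc(NC(=O)c3cc(Cl)cc(Cl)c3)c2)ccc1O`: 15%
Compound 2, `COc1cc(/C=C/C(=O)c2cccc(N)c2)ccc1O`: 20%

Both were tested in a functional assay on HUVEC cells (Homo sapiens) for inhibition, tested at 2.5 ug/mL; a higher number here means a stronger effect of the compound at the concentration tested, a lower number a weaker effect. For the measured compounds named here, compound 1 gives the lower of the two numbers, but its only neighbour, compound 2, sits within the usual scatter of repeated measurements, so the two cannot be told apart on these data. Going by the values given here, the one measured step, a number 5 percentage points higher from compound 1 to compound 2 (within the scatter), replaces the whole (3,5-dichlorophenyl)carbonyl group by a hydrogen and moves the read-out by less than the scatter.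

Compound 3, `COc1cc(/C=C/C(=O)c2cccc(NC(=O)c3ccc(Cl)cc3Cl)c2)ccc1O`, has not yet been measured. It holds the same atoms as compound 1 and differs only in how they are joined: 2,4-dichlorophenyl in place of 3,5-dichlorophenyl on a carbonyl carbon. Among the compounds with values here, no measured step bears on where the two chlorine atoms sit on that ring; the only step at hand removes the group altogether and changes little. With nothing pointing either way, the step of a number 2 percentage points higher from compound 1 to compound 3 (within the scatter) is expected to stay within the scatter. Compound 3 is therefore estimated to give about 17%, with a range from 5% to 35%.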

Compound 3, a percentage reported as inhibition, at one concentration (the size of the read-out at that concentration, not a potency): 29%
For compound 3 the middle estimate is 12 percentage points below the measured one, and the stated range covers the measured number.
By their numbers in this assay, from the lowest: compounds 1, 2 and 3 (each within the scatter of the next, the first and the last beyond it).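

Moving the two chlorine atoms around the ring, with no atom gained or lost, registers in this assay as a number 14 percentage points higher from compound 1 to compound 3 (beyond the scatter) and is the first step here to pass the scatter. The 2,4-dichlorophenyl and 3,5-dichlorophenyl amides therefore cannot be treated as interchangeable at this carbonyl carbon, even though the two groups match in every count of atoms, rings, hydrogen-bond donors and acceptors, and charge. The comparison with the free amine gives a number 9 percentage points higher from compound 2 to compound 3 (within the scatter) and does not show that adding the 2,4-dichlorophenyl amide changes the read-out, while no measurement available here explains why the arrangement of the chlorine atoms matters.

As far as these compounds go, it remains open whether the difference depends on having two chlorine atoms, as a single chlorine, a bromine or a methyl group on the same ring could test this. A read-out at one concentration also leaves open how the potencies of these compounds compare, and all three values come from a single assay on one cell type.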